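From phenyl to tetrafluorophenyl: compound 1 to compound 4

This account rests on a few compounds, and the source may have more. Where it says the series, first, only, none or still open, it means among the compounds named here.

Compound 1 `Cc1c(CCCC(=O)O)c2cccc(/C=C/c3ccc(OCCCCc4ccccc4)cc3)c2n1CC(=O)O` is read in a physicochemical assay for permeability, using PAMPA, with a stated time of 4 h, at pH 7.4, tested at 50 uM (on this read-out higher numbers stand for higher permeability and lower numbers for lower permeability), only as a limit of the assay, not as a number: < 0.05 10^-6 cm/s.

Two other members of the series give numbers. Compound 2 `Cc1c(Cl)cccc1CCCCOc1ccc(C#Cc2cccc3c(CCCC(=O)O)c(C)n(CC(=O)O)c23)cc1` gives 3.2 10^-6 cm/s, and compound 3 `Cc1c(Cl)cccc1CCCCOc1ccc(C#Cc2cccc3c(CCCC(=O)O)c(C)n(CCCCC(=O)O)c23)cc1` gives 5 10^-6 cm/s. Within the data shown here, the only measured step is a 1.6-fold higher number from compound 2 to compound 3 (0.19 log units; within the scatter). It lies within the scatter and concerns a saturated chain carbon bound to an aromatic nitrogen, not the place changed here.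

Compound 4 `Cc1c(CCCC(=O)O)c2cccc(/C=C/c3ccc(OCCCCc4cc(F)c(F)c(F)c4F)cc3)c2n1CC(=O)O` keeps the core of compound 1 and changes one group: 2,3,4,5-tetrafluorophenyl in place of phenyl on a saturated chain carbon, four bonds along the chain from an oxygen on an aromatic ring. This puts 2,3,4,5-tetrafluorophenyl in place of phenyl, four bonds along the chain from an oxygen on an aromatic ring.

Among the measured compounds shown here, no measured step covers this change, so any expectation is loose. Compound 2 at 3.2 10^-6 cm/s shows that the series can give a clear number, so a rise is expected in this assay. A second limit reading remains possible. The expected step is an at least 8.0-fold higher number from compound 1 to compound 4 (0.90 log units; beyond the scatter).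

Compound 4 is estimated at 0.4 10^-6 cm/s, with an expected range of 0.05 10^-6 cm/s to 3 10^-6 cm/s.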

Compound 4, apparent permeability: 0.3 10^-6 cm/s
For compound 4 the middle estimate is 1.3-fold (0.12 log units) above the measured one, within the range that was stated.
By their numbers in this assay, from the lowest: compound 4; then compounds 2 and 3 (each within the scatter of the next). At a limit, below all of these: compound 1.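

In this assay, 2,3,4,5-tetrafluorophenyl in place of phenyl on a saturated chain carbon, four bonds along the chain from an oxygen on an aromatic ring, gives a step beyond the scatter: an at least 6.0-fold higher number from compound 1 to compound 4 (0.77 log units; beyond the scatter). Among these compounds, the size of this step is only a lower bound, because compound 1 stands at a limit of the assay and not at a number: the limit of < 0.05 10^-6 cm/s in this assay, at which 1 of the 4 values shown sits. The earlier compounds gave no reading at this place, and their only step, a 1.6-fold higher number from compound 2 to compound 3 (0.19 log units; within the scatter), lies within the scatter and concerns a saturated chain carbon bound to an aromatic nitrogen.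

From the compounds shown here alone, how a phenyl carrying a single fluorine, or a pyridine ring, would read at this place stays open. Going by these compounds, the true size of the step also stays open, as does whether the same change would give a step on compound 2.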